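This account rests on a few compounds, and the source may have more. Where it says the series, first, only, none or still open, it means among the compounds named here.

Of the compounds shown here, three that share one core have been measured. In a functional assay on MCF7 cells (Homo sapiens) for inhibition, read by sulforhodamine B assay, with a stated time of 48 h, tested at 50 uM (a lower number here means less inhibition of growth, a higher number more inhibition of growth at the concentration tested), compound 1 `COc1ccc([C@@H]2C/C(=N/OCc3cn(-c4ccc(Cl)cc4C)nn3)c3cc(CC=C(C)C)c(OC)cc3O2)cc1` gives 37%. Compound 2 `COc1cc2c(cc1CC=C(C)C)C(=O)C[C@@H](c1ccc(Oc3ccccc3)cc1)O2` gives 69% in this assay, and compound 3 `CCOc1ccc([C@@H]2CC(=O)c3cc(CC=C(C)C)c(OC)cc3O2)cc1` gives 57%. Compound 3 therefore stands second highest of the three numbers: compound 2 lies above it and compound 1 lies below it, and both gaps are beyond the usual scatter of this kind of measurement. Among the compounds with values here, only one measured step changes a single place, namely a number 12 percentage points lower from compound 2 to compound 3 (beyond the scatter), where ethyl takes the place of phenyl on an oxygen on an aromatic ring.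

Compound 4 `COc1cc2c(cc1CC=C(C)C)C(=O)C[C@@H](c1ccc(Oc3ccc(F)cc3)cc1)O2` has not yet been measured. It differs from compound 3 in one place: 4-fluorophenyl in place of ethyl on an oxygen on an aromatic ring. This is close to the reverse of the measured step, with an aromatic ring entering again, now carrying a fluorine. Because a number 12 percentage points lower from compound 2 to compound 3 (beyond the scatter) was a modest fall beyond the scatter, returning an aromatic ring at the same place is expected to bring a rise of similar size, with the fluorine adding an uncertainty that the data cannot resolve. Compound 4 is therefore expected to give about 68% in this assay, with a likely range from 55% to 80%. This estimate corresponds to an expected step of a number 11 percentage points higher from compound 3 to compound 4 (beyond the scatter).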

Compound 4, percent growth inhibition at one concentration: 37%
For compound 4 the middle estimate is 31 percentage points above the measured one; measured number outside the range, below it.
By their numbers in this assay, from the lowest: compounds 1 and 4 (each within the scatter of the next); then compound 3; then compound 2.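

In this assay, the earlier step from phenyl to ethyl could suggest that an aromatic ring on this oxygen supports growth inhibition, but 4-fluorophenyl in place of ethyl gives a number 20 percentage points lower from compound 3 to compound 4 (beyond the scatter), so an aromatic ring here does not raise the number by itself. The more striking result is that fluoro in place of hydrogen on an aromatic carbon gives a number 32 percentage points lower from compound 2 to compound 4 (beyond the scatter), a large change from a single atom, which shows that the outer ring of this group is far from indifferent to small edits. The three groups at this place therefore form no simple order from small to large, since ethyl in compound 3 lies between phenyl in compound 2 and 4-fluorophenyl in compound 4, and nothing available here explains the fall.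

The compounds shown leave open whether the loss belongs to fluorine in particular or would also follow from another group in its place, such as chloro, methyl or methoxy. They also leave open how a longer chain on the oxygen, such as butyl or benzyl, would compare with ethyl and with the two aromatic groups.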